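Ring-size swap on the ring nitrogen of compound 2

The compounds below may be only part of what the source reports. "The series", "measured", "known", "first", "only" and "open" are said of these compounds alone.

Among the compounds with values here, compound 2 `CN1CCC(Cn2nc(Cc3ccc(Cl)cc3)c3ccccc3c2=O)C1` is the only member of this pair with a number in an assay for binding affinity to Alpha-1B adrenergic receptor (Homo sapiens); a lower number here means a stronger inhibitor, a higher number a weaker inhibitor: compound 2 gives 79.4 nM. Compound 1 `COc1cccc(Cc2nn(C[C@H]3CCCN3C)c(=O)c3ccccc23)c1` reaches only a limit in this assay, as compound 1 gives > 1990 nM. That limit is the limit of > 1990 nM in this assay, at which 1 of the 2 values shown sits. Compound 3 `CN1CCC(n2nc(Cc3ccc(Cl)cc3)c3ccccc3c2=O)CC1` is not yet measured; it differs from compound 2 by 1-methylpiperidin-4-yl in place of (1-methylpyrrolidin-3-yl)methyl on an aromatic nitrogen. Within the data shown here, no measured step of this kind exists here, so the step of a 1.3-fold higher number from compound 2 to compound 3 (0.10 log units; within the scatter) is expected to be small, near the scatter. Compound 3 is estimated at about 100 nM in this assay, within 30 nM to 400 nM.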

Compound 3, inhibition constant: 6.31 nM
The estimate for compound 3 lay 16-fold (1.20 log units) above the measured number; measured number below the stated range.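

Putting 1-methylpiperidin-4-yl in place of (1-methylpyrrolidin-3-yl)methyl on the aromatic nitrogen gives a 13-fold lower number from compound 2 to compound 3 (1.10 log units; beyond the scatter) in this assay. Within the data shown here, this shows that the position responds strongly to how these same atoms are joined, which no earlier pair could show. Nothing measured here accounts for the size of this step. Still open, going by these compounds, is whether a two-carbon chain between the aromatic nitrogen and the 1-methylpiperidin-4-yl ring would keep this level, and whether a piperidine without the methyl group on its nitrogen would do so.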